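Aryl swap on the sulfonyl group: cytotoxicity notes

This account rests on a few compounds, and the source may have more. Where it says the series, first, only, none or still open, it means among the compounds named here.

In a functional assay on HEK293 cells (Homo sapiens) for cytotoxicity (on this read-out higher numbers stand for lower toxicity in this test and lower numbers for higher toxicity in this test), compound 1 `COc1ccc([C@H]2CC(=O)N(c3ccccc3)C2)cc1OC1CCCC1` gives > 10000 nM as a limit and not a number.

Compound 2 `COc1ccc([C@H]2CC(=O)N(c3cccc(NCCCc4ccccc4)c3)C2)cc1OC1CCCC1` gives > 10000 nM as a limit as well.

Compound 3 `COc1ccc([C@H]2CC(=O)N(c3cccc(NS(=O)(=O)c4cccc(Cl)c4)c3)C2)cc1OC1CCCC1` gives > 10000 nM as a limit too, so it has no number of its own. Within the data shown here, the whole series so far comes down to the limit of > 10000 nM in this assay, at which 3 of the 3 values shown sit, and nothing orders the three compounds.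

Compound 4 `COc1ccc([C@H]2CC(=O)N(c3cccc(NS(=O)(=O)c4ccccc4F)c3)C2)cc1OC1CCCC1` is the next to be read. The change 2-fluorophenyl in place of 3-chlorophenyl on a sulfonyl sulfur puts 2-fluorophenyl in place of 3-chlorophenyl on a sulfonyl sulfur whose other neighbours are: sulfonamide nitrogen.

The nearest measured steps are a step that the two limits leave unreadable from compound 1 to compound 3 and a step that the two limits leave unreadable from compound 2 to compound 3 and neither has a readable size. Among the measured compounds shown here, no measured step alters the aryl group on the sulfonyl sulfur, so no direct precedent exists for this swap.

Resting on compound 3 and its limit of > 10000 nM in this assay the expected step is a step that the limit leaves unreadable from compound 3 to compound 4 with no shift beyond the scatter and no direction favoured.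

For compound 4 the estimated value is 15000 nM within an expected range from 7000 nM to 30000 nM and a limit is expected again as the most likely reading.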

Compound 4, half-maximal cytotoxic concentration: > 10000 nM
Compound 4: a limit, no number (the forecaster's own chance of this, stated with the estimate: 85%); the middle value lies beyond the limit too.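

Compound 4 gives > 10000 nM in this assay, a limit and not a number. Among these compounds, no step from compound 1, compound 2 or compound 3 to compound 4 can be read. The compounds shown leave open whether any of these changes, the aryl swap on the sulfonyl sulfur included, orders the series at all, with every value at one point: the limit of > 10000 nM in this assay, at which 4 of the 4 values shown sit.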